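Benzyl for Cyclopropyl on a Shared Core

The source may hold more compounds than are shown below. What is called first, only, known or untested is meant among the compounds shown, and "the series" means these compounds.

Measured so far:
Compound 1 `O=C1C(NC2CC2)=CC(=O)c2c1nc1n2[C@H]2OC[C@@H](O)[C@H]2OC1` — > 4000 nM
Compound 2 `CCOc1ccc(NC2=CC(=O)c3nc4n(c3C2=O)[C@H]2OC[C@@H](O)[C@H]2OC4)cc1` — 1110 nM

Of the compounds shown here, two have been tested in a functional assay on MGC-803 cells (Homo sapiens) for inhibition, read by sulforhodamine B assay; on this read-out lower numbers stand for stronger inhibition and higher numbers for weaker inhibition. For compound 1 the reading > 4000 nM is a limit of the assay and not a number. Going by these compounds, that places compound 1 at the limit of > 4000 nM in this assay, at which 1 of the 2 values shown sits, so its true potency is unknown beyond that. Compound 2 gives 1110 nM in this assay, a measured number rather than a limit.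

Compound 3 `O=C1C(NCc2ccccc2)=CC(=O)c2c1nc1n2[C@H]2OC[C@@H](O)[C@H]2OC1` has not yet been measured. It differs from compound 1 in one place: benzyl in place of cyclopropyl on an amine nitrogen. Within the data shown here, no pair of measured compounds shows this change, so the size of its effect cannot be read from the data; only the two values above frame the expectation. Because compound 1 sits at the limit of > 4000 nM in this assay, at which 1 of the 2 values shown sits, any move toward a measured number would be a move toward stronger inhibition, and a modest move of that kind is expected, read as an at least 1.3-fold lower number from compound 1 to compound 3 (0.12 log units; that floor lies within the scatter). Compound 3 is therefore estimated at 3000 nM, with a range from 800 nM to 15000 nM.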

Compound 3, half-maximal inhibitory concentration: 3490 nM
Estimate against measurement, compound 3: 1.2-fold (0.07 log units) below; low and high end bracket the measured number.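

In this assay, among these compounds, benzylamino in place of cyclopropylamino on this amine nitrogen gives the first step that can be read at this position of the shared core, and it reads as an at least 1.1-fold lower number from compound 1 to compound 3 (0.05 log units; that floor lies within the scatter). This shows that a larger carbon-only aromatic ring on a single carbon link can stand here and still give a measured number where the cyclopropyl compound gives only a limit, but the printed floor lies within the scatter, so no gain of assured size can be claimed for the change. Compound 1 carries a limit of the assay, and the step has only a floor and no measured size because of that limit: the limit of > 4000 nM in this assay, at which 1 of the 3 values shown sits.

The compounds shown leave open whether the benzyl ring itself or merely the larger group matters, which a plain propyl chain or a longer unbranched alkyl chain on the same nitrogen could help to separate. They also leave open how the read-out would respond to a methoxy group, a chlorine atom or a carboxylic acid on the benzyl ring.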